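Swapping a Pyrazole Amide for a Methylcyclopropyl Amide

A few compounds are considered here, and "the series" means these few. Any claim that something is new, unique, unknown or untested is made for them only; others in the source may bear on it.

Measured so far, in a physicochemical assay for solubility; on this read-out higher numbers stand for higher solubility and lower numbers for lower solubility:
Compound 1, `CNC(=O)c1cc(C(=O)N[C@H]2CC[C@H](O)CC2)cc2c1OC[C@@]2(C)c1ccccc1`, gives >= 161 ug/mL.
Compound 2, `CNC(=O)c1cc(C(=O)Nc2cnn(C)c2)cc2c1OC[C@H]2c1ccccc1`, gives >= 189 ug/mL.
Compound 3, `CNC(=O)c1cc(C(=O)N[C@H]2[C@@H]3COC[C@@H]32)cc2c1OC[C@H]2c1cccc2[nH]ccc12`, gives >= 171 ug/mL.

Each of these three values is a limit of this assay rather than an exact number. Compound 2 therefore stands at a limit, (the limit of >= 189 ug/mL in this assay, at which 1 of the 3 values shown sits). Compound 1 likewise sits at a limit, (the limit of >= 161 ug/mL in this assay, at which 1 of the 3 values shown sits). Compound 3 also sits at a limit, (the limit of >= 171 ug/mL in this assay, at which 1 of the 3 values shown sits). With only limits available, no ordering of the three compounds can be read from these numbers.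

Compound 4, `CNC(=O)c1cc(C(=O)N[C@H]2C[C@@H]2C)cc2c1OC[C@H]2c1ccccc1`, has not yet been measured in this assay. It differs from compound 2 in one place: 2-methylcyclopropyl in place of 1-methyl-1H-pyrazol-4-yl on an amide-type nitrogen. Going by the values given here, no measured pair of compounds shows this kind of change, so there is no directly comparable step to lean on.

The expectation for compound 4 is a value of 120 ug/mL, between 30 ug/mL and 200 ug/mL. This estimate means a step of an at least 1.5-fold lower number from compound 2 to compound 4 (0.19 log units; that floor lies within the scatter), expected to be modest and downward, possibly still within the scatter, since compound 2 itself is known only as a limit, (the limit of >= 189 ug/mL in this assay, at which 1 of the 3 values shown sits).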

Compound 4, solubility: >= 76 ug/mL
Compound 4 was reported as a limit; the forecaster's own chance of this, stated with the estimate: 45%; the middle value is on the limit's open side.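

In this assay, compound 4 gives >= 76 ug/mL, which is a limit and not an exact number. Going by these compounds alone, compound 2 is also known only as a limit, so no step from compound 2 to compound 4 can be read. Going by these compounds, whether 2-methylcyclopropyl in place of 1-methyl-1H-pyrazol-4-yl changes solubility at all remains open.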